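A Trifluoromethoxy Group Joins a Potent Amidine

The source may report more compounds than this note shows. Statements on the series, on what has been measured and on what is new or still open speak of the compounds shown alone.

Two close relatives open this series. Compound 1 `CCN(CC)/C(C)=N/C1=Nc2ccccc2CS1` carries a diethyl amidine side chain on the shared core, and in a functional assay (strain Wistar) with Rattus norvegicus as the target, read by LDH release (on this read-out higher numbers stand for an effect only at larger amounts of compound and lower numbers for an effect already at smaller amounts), compound 1 gives 0.1 uM. Compound 2 `CCCN(CCC)/C(C)=N/C1=Nc2ccccc2CS1` has propyl chains in place of ethyl, and in this assay compound 2 gives 0.1 uM. The two numbers agree at the digits printed, so compound 2 stands level with compound 1, with no change beyond the usual scatter. A third compound, compound 3 `NC1=Nc2ccc(OC(F)(F)F)cc2CS1`, lacks the amidine side chain altogether but carries trifluoromethoxy on the aromatic ring; in this assay compound 3 gives "not active" (no number reported), with no number reported.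

The compound still to be measured is compound 4 `CCCN(CCC)/C(C)=N/C1=Nc2ccc(OC(F)(F)F)cc2CS1`. It keeps the dipropyl amidine of compound 2 and differs from it in one place: trifluoromethoxy in place of hydrogen on an aromatic carbon. Among the compounds with values here, no measured pair shows this exact change, so its size cannot be read from the data. Within the data shown here, compound 3 shows only that the substituted ring without the side chain gave no number, and says nothing about the substituted ring together with the side chain.

Compound 4 is expected to land near 0.3 uM, within a range from 0.05 uM to 3 uM. The step of a 3.0-fold higher number from compound 2 to compound 4 (0.48 log units; beyond the scatter) that this estimate means is expected to be a modest weakening, close to the edge of the scatter.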

Compound 4, minimum effective concentration: 0.1 uM
Beside the measured number, compound 4's estimate is 3.0-fold (0.48 log units) above it, and the stated range covers the measured number.
By their numbers in this assay, from the lowest: compounds 1, 2 and 4 (each within the scatter of the next).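

Putting trifluoromethoxy in place of hydrogen on this aromatic carbon, the one that stands meta to a fused ring and para to a fused ring, gives no change at the digits printed from compound 2 to compound 4 (within the scatter) in this assay, so this place on the ring accepts a group of 5 heavy atoms without a shift in the read-out beyond normal experimental variation. Compound 3 carries the same ring group without the amidine side chain and is reported as not active with no number, whereas compound 4, with the dipropyl amidine added, gives 0.1 uM, so the ring group does not prevent a strong reading when that side chain is present. No supporting measurement is available to explain why the number holds steady after this sizeable addition.

From the compounds shown here alone, whether this tolerance extends to other groups at the same place, such as a methoxy group, a chlorine atom, an amine or a carboxylic acid, remains open. Going by these compounds, it is also open whether trifluoromethoxy would behave the same way on other ring carbons or alongside the diethyl amidine of compound 1.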